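Removing the para-fluorine from a chalcone lactam

This account rests on a few compounds, and the source may have more. Where it says the series, first, only, none or still open, it means among the compounds named here.

For the measured compounds named here, the two compounds measured so far share one core and differ only in the aryl group on the double-bonded chain. Compound 1 `O=C(COc1ccc(C(=O)/C=C/c2ccccc2Cl)cc1)N[C@H]1CCOC1=O` carries a 2-chlorophenyl there, and in a functional assay on DU-145 cells (Homo sapiens) for antiproliferative activity, read by MTT assay, with a stated time of 72 h (a higher number here means a weaker inhibitor, a lower number a stronger inhibitor), compound 1 gives 3240 nM. Compound 2 `O=C(COc1ccc(C(=O)/C=C/c2ccc(F)cc2)cc1)N[C@H]1CCOC1=O` carries a 4-fluorophenyl instead, and in this assay compound 2 gives 18800 nM, the higher of the two numbers; the change is a 5.8-fold higher number from compound 1 to compound 2 (0.76 log units; beyond the scatter). Compound 3 `O=C(COc1ccc(C(=O)/C=C/c2ccccc2)cc1)N[C@H]1CCOC1=O` has not yet been measured. It differs from compound 2 by hydrogen in place of fluoro on an aromatic carbon; in other words the 4-fluorophenyl becomes a plain phenyl. Going by the values given here, no measured step removes a fluoro, so the only step available, a 5.8-fold higher number from compound 1 to compound 2 (0.76 log units; beyond the scatter), bears on it indirectly: it shows that the aryl group matters, but it swaps two different substituted rings rather than stripping one substituent. Removing a single fluoro is usually a small change, and compound 3 is therefore expected to land near compound 2, with a step of a 1.6-fold lower number from compound 2 to compound 3 (0.19 log units; within the scatter) in this assay. The estimate for compound 3 is 12000 nM, within a range of 4000 nM to 35000 nM.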

Compound 3, half-maximal inhibitory concentration: 48300 nM
Compound 3: the middle estimate sits 4.0-fold (0.60 log units) below what was measured; measured number outside the range, above it.
By their numbers in this assay, from the lowest: compound 1; then compound 2; then compound 3.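

Fluoro on this ring is not a negligible detail: in this assay, replacing it with hydrogen on the aromatic carbon para to a large group gives a step beyond the scatter (a 2.6-fold higher number from compound 2 to compound 3 (0.41 log units; beyond the scatter)), so even this one-atom change registers at this position. The plain phenyl of compound 3 also separates clearly from the 2-chlorophenyl of compound 1 (a 15-fold higher number from compound 1 to compound 3 (1.17 log units; beyond the scatter)), which makes compound 3 the weakest of the three and shows that, among these compounds, either halogen gives a lower number than hydrogen, with the larger step belonging to chloro. No measurement here accounts for these differences in terms of any property of the groups or the ring.

Compound 1 and compound 2 differ in both the halogen and its place on the ring, so the compounds shown cannot tell whether the larger step comes from chloro itself or from where it sits, and chloro on the carbon that holds fluoro in compound 2 would help separate the two. As far as these compounds go, it also remains open whether this gain is peculiar to halogens or would appear with a methyl, methoxy or amine group on that same carbon.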